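The compounds below may be only part of what the source reports. "The series", "measured", "known", "first", "only" and "open" are said of these compounds alone.

Compound 1, `Fc1cccc(F)c1Cn1ccc2nc(-c3c(F)cccc3F)nc-2c1`: in an ADME assay on MDBK cells (Bos taurus) for cytotoxicity (a higher number here means that more compound is tolerated, a lower number that less compound is tolerated), compound 1 gives > 100000 nM, which is a limit of the assay rather than a number.
Compound 2, `Fc1ccccc1Cn1ccc2nc(-c3ccccc3)nc-2c1`: in this assay compound 2 gives > 100000 nM, again a limit of the assay and not a number.

Compound 2 therefore stands where every value shown stands: both measured compounds sit at the limit of > 100000 nM in this assay, at which 2 of the 2 values shown sit, so no compound here has shown measurable harm to the cells, and nothing separates compound 1 from compound 2 on these numbers.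

Compound 3, `c1ccc(-c2nc3ccn(Cc4ccccn4)cc-3n2)cc1`, has not yet been measured. It differs from compound 2 in one place: pyridin-2-yl in place of 2-fluorophenyl on a saturated chain carbon bound to an aromatic nitrogen. Going by the values given here, no step between two measured compounds is available to say how much such a change moves the read-out. With both known values at the limit, the expected step of a number no higher from compound 2 to compound 3 (the limit leaves the size open) in this assay is none beyond the scatter. Compound 3 is thus expected to give about 100000 nM in this assay, with a range from 30000 nM to 300000 nM, most likely reported once more as a limit.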

Compound 3, half-maximal cytotoxic concentration: > 100000 nM
Compound 3 was reported as a limit; the forecaster's own chance of this, stated with the estimate: 80%; the middle value lies on the limit itself.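

Compound 3 sits at the same limit as compound 2, so no step can be read between them: the limit of > 100000 nM in this assay, at which 3 of the 3 values shown sit.

The compounds shown leave open the concentration at which any of them would harm the cells, and so whether 2-fluorophenyl and pyridin-2-yl differ at all in this assay once a real number is available.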